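A few compounds are considered here, and "the series" means these few. Any claim that something is new, unique, unknown or untested is made for them only; others in the source may bear on it.

Compound 1 `FC(F)(F)c1ccc(C2CC(c3ccc4c(c3)OCCO4)=NN2c2ccccc2)cc1`, compound 2 `Clc1ccc(C2CC(c3ccc4c(c3)OCCO4)=NN2c2ccccc2)cc1` and compound 3 `Brc1ccc(C2CC(c3ccc4c(c3)OCCO4)=NN2c2ccccc2)cc1` share a core. In a functional assay on WM 266-4 cells (Homo sapiens) for antiproliferative activity, read by MTT assay, with a stated time of 24 h (a higher number here means a weaker inhibitor of growth, a lower number a stronger inhibitor of growth), compound 1 reads > 100000 nM, which is a limit of the assay. Compound 2 gives 38600 nM, and compound 3 gives 3010 nM, the lowest number of the three. Compound 4 `Clc1cccc(C2CC(c3ccc4c(c3)OCCO4)=NN2c2ccccc2)c1` differs from compound 3 as follows: 3-chlorophenyl in place of 4-bromophenyl on a saturated ring carbon. In words, 3-chlorophenyl stands in place of 4-bromophenyl on a saturated ring carbon. The closest guide is a 13-fold lower number from compound 2 to compound 3 (1.11 log units; beyond the scatter), a large step for bromo in place of chloro, and compound 4 has chloro rather than bromo. Among the measured compounds shown here, no measured compound carries 3-chlorophenyl, so the range stays wide. A rise in the number in this assay is expected, a 6.6-fold higher number from compound 3 to compound 4 (0.82 log units; beyond the scatter). Compound 4 is estimated at 20000 nM, with an expected range of 4000 nM to 90000 nM.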

Compound 4, concentration for 50% growth inhibition: 1750 nM
Compound 4: middle estimate off by 11-fold (1.06 log units), on the high side; the whole stated range lies above it.
By their numbers in this assay, from the lowest: compounds 4 and 3 (each within the scatter of the next); then compound 2. At a limit, above all of these: compound 1.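

With a 22-fold lower number from compound 2 to compound 4 (1.34 log units; beyond the scatter), 3-chlorophenyl in place of 4-chlorophenyl shows that, on this saturated ring carbon, the place of the chloro on the phenyl counts, not only the choice of halogen. In this assay, a 1.7-fold lower number from compound 3 to compound 4 (0.24 log units; within the scatter) leaves 3-chlorophenyl and 4-bromophenyl indistinguishable, so a chloro compound can now match the bromo one. The step of an at least 57-fold lower number from compound 1 to compound 4 (1.75 log units; beyond the scatter) starts from a limit of the assay: the limit of > 100000 nM in this assay, at which 1 of the 4 values shown sits.

As far as these compounds go, it stays open whether bromo or trifluoromethyl follows chloro when shifted in the same way. From the compounds shown here alone, how a carboxylic acid or an amine on that phenyl would read also stays open.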